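The source may report more compounds than this note shows. Statements on the series, on what has been measured and on what is new or still open speak of the compounds shown alone.

Compound 1 `O=C1NC(c2ccccc2)CN1S(=O)(=O)c1ccccc1`: 145000 nM
Compound 2 `Cc1ccc(C2CN(S(=O)(=O)c3ccc(Cl)cc3)C(=O)N2)cc1`: 158000 nM

Of the compounds shown here, two have been measured in a functional assay on A549 cells (Homo sapiens) for cytotoxicity; on this read-out lower numbers stand for stronger inhibition and higher numbers for weaker inhibition. In this assay compound 2 gives 158000 nM, which lies within the scatter of compound 1 at 145000 nM. The next compound to be tested is compound 3 `O=C1NC(c2ccccc2)CN1S(=O)(=O)c1ccc(Cl)cc1`. It departs from compound 2 by one change: hydrogen in place of methyl on an aromatic carbon. In words, hydrogen takes the place of methyl on an aromatic carbon, turning 4-methylphenyl into phenyl. Within the data shown here, no measured pair isolates this change. Among the measured compounds shown here, the only guide is that compound 1 at 145000 nM and compound 2 at 158000 nM sit within the scatter of each other. The expected step of a 1.1-fold lower number from compound 2 to compound 3 (0.02 log units; within the scatter) therefore stays within the scatter, with neither direction favoured. For compound 3 the estimated value is 150000 nM, with an expected range of 80000 nM to 280000 nM.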

Compound 3, half-maximal inhibitory concentration: 9470 nM
Beside the measured number, compound 3's estimate is 16-fold (1.20 log units) above it; the measured number lies below the stated range.
By their numbers in this assay, from the lowest: compound 3; then compounds 1 and 2 (each within the scatter of the next).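

In this assay, replacing methyl with hydrogen on the aromatic carbon, which turns 4-methylphenyl into phenyl, gives a 17-fold lower number from compound 2 to compound 3 (1.22 log units; beyond the scatter), so this position is sensitive to a single added carbon when the chloro group is present. Chloro in place of hydrogen on an aromatic carbon gives a 15-fold lower number from compound 1 to compound 3 (1.19 log units; beyond the scatter), showing that this change also has a large effect when the phenyl group is present, something the earlier pair, which differ in two places, could not separate. Nothing available explains either step.

The compounds shown leave open how a methoxy group, an amine or a fluoro group would read at the carbon that carries methyl in compound 2. They also leave open whether chloro and hydrogen at these two places would give the same steps on the core with other groups attached.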